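Swapping one aryl group on a pyrazoline core

The compounds below may be only part of what the source reports. "The series", "measured", "known", "first", "only" and "open" are said of these compounds alone.

Compound 1 `CC(=O)N1N=C(c2cc(O)c(O)c([N+](=O)[O-])c2)CC1c1ccc(C#N)cc1` was tested in an assay on isolated protein for inhibition of Amine oxidase [flavin-containing] B (Homo sapiens), read by fluorescence (on this read-out higher numbers stand for weaker inhibition and lower numbers for stronger inhibition), where compound 1 gives 83200 nM. Compound 2 `N#Cc1ccc(/C=C/C(=O)c2cc(O)c(O)c([N+](=O)[O-])c2)cc1` gives 56600 nM in this assay, and compound 3 `O=C(/C=C/c1ccco1)c1cc(O)c(O)c([N+](=O)[O-])c1` gives 68200 nM. Compound 1 has the highest of these three numbers, yet its gaps to compound 3 and to compound 2 both lie within the usual scatter, so no order among them can be claimed. Compound 4 `CC(=O)N1N=C(c2cc(O)c(O)c([N+](=O)[O-])c2)CC1c1cccc(O)c1` differs from compound 1 by 3-hydroxyphenyl in place of 4-cyanophenyl on a saturated ring carbon. Within the data shown here, no measured pair shows this change. Since every number here sits in the same weak region, the step is expected to be small, with no clear direction beyond the scatter a 1.2-fold lower number from compound 1 to compound 4 (0.08 log units; within the scatter). Compound 4 is therefore estimated at 70000 nM, within a range from 25000 nM to 200000 nM.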

Compound 4, half-maximal inhibitory concentration: 85200 nM
Estimate against measurement, compound 4: 1.2-fold (0.09 log units) below; the measured number falls inside the stated range.
By their numbers in this assay, from the lowest: compounds 2, 3, 1 and 4 (each within the scatter of the next).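

Among these compounds, putting 3-hydroxyphenyl in place of 4-cyanophenyl on the saturated ring carbon gives a 1.0-fold higher number from compound 1 to compound 4 (0.01 log units; within the scatter) in this assay, the first single-place comparison on this core. The two compounds cannot be told apart, so at this position these two aryl groups read alike, and both compounds stay in the weak region. Nothing available explains this result.

The compounds shown leave open whether any group on this carbon can shift the number beyond the scatter. An aminophenyl group, a carboxyphenyl group or a longer alkyl chain there would be untested cases.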